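Swapping the Benzyl Group: From Compound 2 to Compound 4

A few compounds are considered here, and "the series" means these few. Any claim that something is new, unique, unknown or untested is made for them only; others in the source may bear on it.

Compound 1 `Cc1cc(Nc2cc(-c3ccccc3)[nH]n2)n2ncnc2n1`: in an ADME assay on GES1 cells (Homo sapiens) for inhibition, read by MTT assay, with a stated time of 72 h (a lower number here means a stronger inhibitor, a higher number a weaker inhibitor), compound 1 gives > 50000 nM, which is a limit of the assay and not a number.
Compound 2 `Cc1cc(Nc2cc(-c3ccccc3)[nH]n2)n2nc(SCc3c(Cl)cccc3Cl)nc2n1`: compound 2 gives 39600 nM.
Compound 3 `Cc1cc(Nc2ccn(Cc3nc(C)c4ccccc4n3)n2)n2nc(SCc3ccc(Br)cc3)nc2n1`: compound 3 gives 36800 nM.

Of the two numbers measured, compound 2 has the highest, but compound 3 is nearest and sits within the scatter, so no order between them can be read. Among the compounds with values here, only one measured step exists, an at least 1.2-fold lower number from compound 1 to compound 2 (0.10 log units; that floor lies within the scatter), in which a sulfanyl-linked benzyl group is added to the shared core. Compound 1 sits at the limit of > 50000 nM in this assay, at which 1 of the 3 values shown sits, so the real size of that step is not known. Compound 4 `Cc1cc(Nc2cc(-c3ccccc3)[nH]n2)n2nc(SCc3ccc(C(F)(F)F)cc3)nc2n1` differs from compound 2 by 4-(trifluoromethyl)phenyl in place of 2,6-dichlorophenyl on a saturated chain carbon bound to a sulfur. Within the data shown here, no measured step changes only the substituents on that benzyl ring, and the one step that touches this part of the molecule gives no direction beyond the scatter. Compound 4 is therefore expected to give 40000 nM, in a range from 20000 nM to 80000 nM. That estimate means an expected step of a 1.0-fold higher number from compound 2 to compound 4 (0.00 log units; within the scatter), within the scatter.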

Compound 4, half-maximal inhibitory concentration: 42700 nM
Compound 4: the middle estimate sits 1.1-fold (0.03 log units) below what was measured; low and high end bracket the measured number.
By their numbers in this assay, from the lowest: compounds 3, 2 and 4 (each within the scatter of the next). At a limit, above all of these: compound 1.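

In this assay, going from the 2,6-dichlorobenzyl group to the 4-(trifluoromethyl)benzyl group gives a 1.1-fold higher number from compound 2 to compound 4 (0.03 log units; within the scatter). The earlier step could show only what happened when a whole sulfanyl-linked benzyl group was added to the shared core, whereas this step keeps that link and exchanges only the ring at its end. For this one pair, the two rings cannot be told apart in this assay, so the exchange gives no direction for the position.

Going by these compounds, whether a group without a ring, such as a longer alkyl chain, or a benzyl ring carrying an amine or a carboxylic acid, would move the number stays open. The size of the step made by adding the sulfanyl-linked group also stays unknown, because compound 1 stands at a limit: the limit of > 50000 nM in this assay, at which 1 of the 4 values shown sits.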